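A few compounds are considered here, and "the series" means these few. Any claim that something is new, unique, unknown or untested is made for them only; others in the source may bear on it.

Of the compounds shown here, three built on one shared core have been measured in an assay on membranes from HEK293 cells for displacement of a labelled ligand from adenosine receptor A2b (Homo sapiens), read by scintillation counting, with a stated time of 30 min; a higher number here means a weaker inhibitor, a lower number a stronger inhibitor. Compound 3 `CC1=C(C(=O)CC(C)C)C(c2ccco2)NC(=O)N1` gives 240 nM, the lowest number of the three. Compound 1 `CCCOC(=O)C1=C(C)NC(=O)NC1c1ccoc1` gives 1190 nM, and compound 2 `CC1=C(C(=O)OC(C)(C)C)C(c2ccoc2)NC(=O)N1` gives 4440 nM. Among the compounds with values here, the only pair of measured compounds that differ in a single place is the pair giving a 3.7-fold higher number from compound 1 to compound 2 (0.57 log units; beyond the scatter), a change of the ester group and not of the furan ring. Compound 4 `CC1=C(C(=O)CC(C)C)C(c2ccoc2)NC(=O)N1` differs from compound 3 in a different way: furan-3-yl in place of furan-2-yl on a saturated ring carbon. Compounds 1 and 2 both carry the furan-3-yl ring, but they also carry an ester where compound 3 carries a ketone, so their numbers cannot separate the furan change from the ester change. Within the data shown here, no measured step therefore bears directly on the move from compound 3 to compound 4, and the expectation rests on the lack of any sign of a large shift: a step of a 1.7-fold higher number from compound 3 to compound 4 (0.22 log units; within the scatter) is expected, with the direction uncertain. Compound 4 is estimated at 400 nM, within a range from 130 nM to 1200 nM.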

Compound 4, inhibition constant: 1010 nM
Estimate against measurement, compound 4: 2.5-fold (0.40 log units) below; low and high end bracket the measured number.
By their numbers in this assay, from the lowest: compound 3; then compounds 4 and 1 (each within the scatter of the next); then compound 2.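

In this assay the point of attachment of the furan matters at this position: furan-3-yl in place of furan-2-yl on the saturated ring carbon gives a 4.2-fold higher number from compound 3 to compound 4 (0.62 log units; beyond the scatter) even though the two groups have the same atoms. With furan-3-yl held in place, the group on the carbonyl can also be compared: isobutyl in place of tert-butoxy gives a 4.4-fold lower number from compound 2 to compound 4 (0.64 log units; beyond the scatter) while isobutyl in place of propoxy gives a 1.2-fold lower number from compound 1 to compound 4 (0.07 log units; within the scatter) and stays within the scatter. The low number of compound 3 therefore goes with furan-2-yl and not with the isobutylcarbonyl group alone, which compound 4 also carries.

From the compounds shown here alone, whether furan-2-yl would lower the number in the propyl and tert-butyl esters remains open, as does how a phenyl or thiophen-2-yl ring would compare at this position. Nothing available here explains the difference between the two furan attachments.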